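The compounds below may be only part of what the source reports. "The series", "measured", "known", "first", "only" and "open" are said of these compounds alone.

Measured compounds:
- Compound 1 `Cc1cc(CCOc2ccc(-c3c(C)nc(C)c([C@H](OC(C)(C)C)C(=O)O)c3N3CCC(C)(C)CC3)cc2)ccc1F`: in an ADME assay on microsomes from liver (Homo sapiens) for metabolic stability, read by LC-MS, tested at 0.5 uM (a higher number here means that the compound lasts longer, a lower number that the compound disappears faster), compound 1 gives > 2 h, which is a limit of the assay and not a number.
- Compound 2 `Cc1nc(C)c([C@H](OC(C)(C)C)C(=O)O)c(N2CCC(C)(C)CC2)c1-c1ccc(OCCc2ccc(F)cc2F)cc1`: in this assay compound 2 gives 1.08 h.

Compound 2 holds the only number shown; the other value is the limit (the limit of > 2 h in this assay, at which 1 of the 2 values shown sits). Compound 3 `Cc1nc(C)c([C@H](OC(C)(C)C)C(=O)O)c(N2CCC(C)(C)CC2)c1-c1ccc(OCCCc2ccc(F)cc2)cc1` differs from compound 2 by 4-fluorobenzyl in place of 2,4-difluorophenyl on a saturated chain carbon, two bonds along the chain from an oxygen on an aromatic ring. Among the compounds with values here, the one measured step at that place, an at least 1.8-fold lower number from compound 1 to compound 2 (0.26 log units; that floor lies within the scatter), has a floor within the scatter, so it gives no firm direction. Compound 3 is therefore expected to sit close to compound 2, with an estimated step of a 1.1-fold higher number from compound 2 to compound 3 (0.05 log units; within the scatter). For compound 3 the estimate in this assay is 1.2 h, ranging from 0.5 h to 2.5 h.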

Compound 3, half-life: > 2 h
Compound 3 gave a limit, no number (the forecaster's own chance of this, stated with the estimate: 25%); middle value at least 1.6-fold (0.22 log units) away from the limit.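

The change to 4-fluorobenzyl from 2,4-difluorophenyl in this assay gives an at least 1.8-fold higher number from compound 2 to compound 3 (0.26 log units; that floor lies within the scatter). The value of compound 3 is a limit of the assay and not a number: the limit of > 2 h in this assay, at which 2 of the 3 values shown sit.

Two different groups at this place, in compound 1 and compound 3, therefore sit at that limit, and the step between them cannot be read. The compounds shown leave open whether the longer chain or the loss of one fluorine matters more, since 2-(2,4-difluorophenyl)ethoxy and 3-(4-fluorophenyl)propoxy differ in both. A 3-(2,4-difluorophenyl)propoxy group would separate the two.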